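Aryl variation at one position, adenosine A3 displacement

A few compounds are considered here, and "the series" means these few. Any claim that something is new, unique, unknown or untested is made for them only; others in the source may bear on it.

Values in an assay on CHO cells for displacement of a labelled ligand from adenosine receptor A3 (Homo sapiens), read by scintillation counting, tested at 10 uM; a lower number here means less inhibition, a higher number more inhibition at the concentration tested (going by the name of the read-out):
compound 1 `CC(C)(C)Cc1c(-c2ccc(F)cc2F)sc(N)c1C(=O)c1ccc(Cl)cc1`: 1%
compound 2 `CC(C)(C)Cc1c(-c2c(F)cccc2F)sc(N)c1C(=O)c1ccc(Cl)cc1`: 1%
compound 3 `CC(C)(C)Cc1c(-c2ccccc2)sc(N)c1C(=O)c1ccc(Cl)cc1`: 1%

Compound 3 stands level with compounds 1 and 2 in this assay; its nearest neighbour is compound 1 and its furthest is compound 2, and in both cases the values are within the scatter of each other. The three compounds share one core and differ only in the aryl group on an aromatic carbon of that core.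

The next compound, compound 4 `CC(C)(C)Cc1c(-c2ccsc2)sc(N)c1C(=O)c1ccc(Cl)cc1`, is not yet measured. It differs from compound 3 by thiophen-3-yl in place of phenyl on an aromatic carbon.

Among the measured compounds shown here, the steps that bear on this are those in which the same aryl group was exchanged: no change at the digits printed from compound 1 to compound 3 (within the scatter) and no change at the digits printed from compound 2 to compound 3 (within the scatter), and also no change at the digits printed from compound 1 to compound 2 (within the scatter). None of them moved the read-out beyond the scatter; every measured variant of this group reads the same. On these three steps alone there is no basis for a move in either direction in this assay, so the step from compound 3 to compound 4 is expected to be a number 1 percentage points higher from compound 3 to compound 4 (within the scatter), with the note that all measured changes were among six-membered rings of carbon only, and none placed a five-membered ring with a hetero atom here. Compound 4 is estimated at 2%, within -6% to 12%.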

Compound 4, a percentage reported as inhibition, at one concentration (the size of the read-out at that concentration, not a potency): 4%
Estimate against measurement, compound 4: 2 percentage points below; measured number inside the range.
By their numbers in this assay, from the lowest: compounds 1, 2, 3 and 4 (each within the scatter of the next).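

In this assay, the position on the shared core next to the ring sulfur now also accepts a five-membered aromatic ring with a hetero atom, and thiophen-3-yl stays within the scatter of all three six-membered aryl groups (a number 3 percentage points higher from compound 3 to compound 4 (within the scatter); a number 3 percentage points higher from compound 2 to compound 4 (within the scatter); a number 3 percentage points higher from compound 1 to compound 4 (within the scatter)). Ring size and the ring sulfur of the entering group therefore add nothing that separates compound 4 from compounds 1, 2 and 3 at the concentration tested, which extends the flat reading beyond six-membered rings of carbon only. No measurement is available that would explain this flat reading.

On these data alone, all four compounds read low, so it remains open whether any group at this position can raise the displacement, for example a cyclohexyl ring, a pyridin-3-yl ring, or a phenyl ring carrying a carboxylic acid or an aminomethyl group. As far as these compounds go, it also remains open whether the aryl exchange would read differently with another group in place of the neopentyl group or the amino group.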